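Enlarging an Amide End-Group on a Chromone-Type Kinase Inhibitor

The source may report more compounds than this note shows. Statements on the series, on what has been measured and on what is new or still open speak of the compounds shown alone.

Measured compounds:
Compound 1, `CN(C)c1ccc(C(=O)Nc2cccc(NC(=O)COc3ccc4c(c3)CCC(=O)N4)c2)cc1`: 9970 nM
Compound 2, `CC(=O)Nc1cccc(NC(=O)COc2ccc3c(=O)ccoc3c2)c1`: 136 nM

In an assay on isolated protein for inhibition of Rho-associated protein kinase 2 (Homo sapiens), read by scintillation counting, radiometric assay and 33P incorporation, with a stated time of 40 min, in the presence of a further agent that is not named here (on this read-out higher numbers stand for weaker inhibition and lower numbers for stronger inhibition), compound 2 gives 136 nM, the lowest of the two numbers recorded. Compound 1 gives 9970 nM, a gap that lies well beyond the scatter of repeated measurements. The two compounds differ in more than one place, so no single change can be credited with that gap.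

Compound 3, `CC(C)(C)c1ccc(C(=O)Nc2cccc(NC(=O)COc3ccc4c(=O)ccoc4c3)c2)cc1`, has not yet been measured. Relative to compound 2 the change is 4-(tert-butyl)phenyl in place of methyl on a carbonyl carbon. Within the data shown here, no measured pair shows this change alone, so its effect is open. Compound 1, which also carries an aryl amide at this position on a different core, gives 9970 nM, which leaves room for a weaker result. Compound 3 is expected to give 350 nM, within 60 nM to 2000 nM, meaning an estimated step of a 2.6-fold higher number from compound 2 to compound 3 (0.41 log units; beyond the scatter).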

Compound 3, half-maximal inhibitory concentration: 34 nM
Estimate against measurement, compound 3: 10-fold (1.01 log units) above; the whole stated range lies above it.
By their numbers in this assay, from the lowest: compound 3; then compound 2; then compound 1.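

In this assay, putting 4-(tert-butyl)phenyl in place of methyl on a carbonyl carbon gives a 4.0-fold lower number from compound 2 to compound 3 (0.60 log units; beyond the scatter). On this shared core, then, the position takes a far larger group that brings an aromatic ring, and inhibition gets stronger rather than weaker. Compound 1 also has an aryl amide and gives a much higher number, but it differs from compound 3 in more than one place, so that number cannot be pinned on the group at this position, and nothing here explains why the larger group goes with stronger inhibition.

The compounds shown leave open whether the gain comes from the phenyl ring or from the tert-butyl on it, which a plain phenyl at this position would help separate. Going by these compounds, how an amine or a carboxylic acid on that ring would change the number is also open.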